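A few compounds are considered here, and "the series" means these few. Any claim that something is new, unique, unknown or untested is made for them only; others in the source may bear on it.

Working notes on the series. Compound 1 `CC(C)=CCOc1cccc(O)c1C(=O)/C=C/c1ccc(O)cc1`, compound 2 `COc1cccc(OCCC(C)(C)C)c1C(=O)/C=C/c1ccc(O)cc1` and compound 3 `CC(C)(C)CCOc1cccc(O)c1C(=O)CCc1ccc(O)cc1` have been run in a functional assay on MDA-MB-231 cells (Homo sapiens) for antiproliferative activity, read by sulforhodamine B assay; a lower number here means a stronger inhibitor of growth, a higher number a weaker inhibitor of growth. In this assay compound 1 gives > 30000 nM, a limit of the assay rather than a number. Compound 2 likewise reaches only > 30000 nM in this assay, again a limit. Compound 3 sits at the same limit, > 30000 nM, in this assay. For the measured compounds named here, no step between measured compounds can be drawn, since every value is a limit; what the data show is the limit of > 30000 nM in this assay, at which 3 of the 3 values shown sit. Compound 2 therefore stands at the limit alongside the other two, with no number to rank it by.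

Compound 4 `CC(C)(C)CCOc1cccc(O)c1C(=O)/C=C/c1ccc(O)cc1` is not yet measured. It differs from compound 2 in one place: hydrogen in place of methyl on an oxygen on an aromatic ring. The same change, read one bond further out, is methoxy to hydroxy. Compound 1 and compound 3 already carry the hydroxy on the shared core and both sit at the limit, so the change gives no sign of moving growth inhibition in either direction. The step of a number no higher from compound 2 to compound 4 (the limit leaves the size open) is expected to be none beyond the scatter. Compound 4 is expected to give 30000 nM in this assay, with a range from 15000 nM to 100000 nM, and most probably it will again be reported only as a limit.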

Compound 4, concentration for 50% growth inhibition: 2380 nM
Compound 4: middle estimate off by 13-fold (1.10 log units), on the high side; the measured number lies below the stated range.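

In this assay, for the compounds shown here, the step of an at least 12-fold lower number from compound 2 to compound 4 (1.10 log units; beyond the scatter) is the first measurable effect, and it goes with hydrogen in place of methyl on an oxygen on an aromatic ring, which is methoxy to hydroxy when read one bond further out. The hydroxy alone does not account for the result: compound 1 already carries it, yet the step of an at least 12-fold lower number from compound 1 to compound 4 (1.10 log units; beyond the scatter) appears only with neopentyl in place of 2-methylprop-1-en-1-yl, so among the compounds shown, growth inhibition is measurable only where the hydroxy and the neopentyl-bearing chain occur together. Both steps start from a limit rather than a number, so their true size stays unknown: the limit of > 30000 nM in this assay, at which 3 of the 4 values shown sit.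

The compounds shown leave open how much the chain on the other oxygen can vary, for instance whether a longer chain or a chain ending in an amine or a carboxylic acid keeps the effect. They also leave open whether the free hydroxy can be replaced by anything other than hydrogen on that oxygen, such as an ethyl group or an acetyl group.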